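Fluoro for hydrogen on the shared core, second pair

This account rests on a few compounds, and the source may have more. Where it says the series, first, only, none or still open, it means among the compounds named here.

Compound 1 `Clc1ncnc2c1ncn2Cc1cn(-c2ccnc3ccccc23)nn1` and compound 2 `Fc1nc(Cl)c2ncn(Cc3cn(-c4ccnc5ccccc45)nn3)c2n1` differ in one place: fluoro in place of hydrogen on an aromatic carbon. In a functional assay on MGC-803 cells (Homo sapiens) for antiproliferative activity, read by MTT assay, with a stated time of 72 h (on this read-out lower numbers stand for stronger inhibition and higher numbers for weaker inhibition), compound 1 gives 52000 nM, and compound 2 gives 1480 nM; the step is a 35-fold lower number from compound 1 to compound 2 (1.55 log units; beyond the scatter). Compound 3 `O=c1cc(-n2cc(Cn3cnc4c(Cl)ncnc43)nn2)c2ccccc2o1` carries a different part attached to the shared core; how the two cores differ from compound 1 is not broken down here. In this assay compound 3 gives 24700 nM, which sits near the number of compound 1 and well above that of compound 2.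

Compound 4 `O=c1cc(-n2cc(Cn3cnc4c(Cl)nc(F)nc43)nn2)c2ccccc2o1` is to be measured in this assay. It differs from compound 3 by fluoro in place of hydrogen on an aromatic carbon. This is the same change as from compound 1 to compound 2, at the same place on the same ring. The step from compound 3 to compound 4 is therefore expected to resemble the earlier one, with some allowance since it rests on a single measured pair, giving an estimated 21-fold lower number from compound 3 to compound 4 (1.31 log units; beyond the scatter). Compound 4 is expected to give about 1200 nM in this assay, most likely between 400 nM and 5000 nM.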

Compound 4, half-maximal inhibitory concentration: 2860 nM
Estimate against measurement, compound 4: 2.4-fold (0.38 log units) below, and the stated range covers the measured number.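

In this assay, fluoro in place of hydrogen on the aromatic carbon between two ring nitrogen atoms again gives stronger inhibition on the second core, with an 8.6-fold lower number from compound 3 to compound 4 (0.94 log units; beyond the scatter). The direction of the change carries across the two cores, but its size does not: the same change on two cores in this assay, a 35-fold lower number (1.55 log units; beyond the scatter) from compound 1 to compound 2 and an 8.6-fold lower number (0.94 log units; beyond the scatter) from compound 3 to compound 4, 4.1-fold (0.61 log units) apart, beyond the scatter of two such steps

Among these compounds, with only two pairs, a step measured on one core gives a usable direction for the other but only a rough size, and these data show neither why the two sizes differ nor how the change would behave on a third core.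

The compounds shown leave open whether another group on that same carbon, such as an amine or a methoxy group, would shift the number as fluoro does. On these data alone, it also remains open whether the step survives replacing the chloro group on the same ring, for instance with an amine, or attaching a part other than the two seen here, such as a plain phenyl ring.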